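Replacing the Sulfamide of Compound 3 with a Hydroxyl

A few compounds are considered here, and "the series" means these few. Any claim that something is new, unique, unknown or untested is made for them only; others in the source may bear on it.

Of the compounds shown here, three that share one core have been measured in an assay on CHO cells for antagonist activity at transient receptor potential cation channel subfamily V member 1 (Homo sapiens), read by scintillation counting, with a stated time of 5 min, in the presence of a further agent that is not named here; a higher number here means that more compound is needed for the effect, a lower number that less compound is needed. Compound 1 `CN(C)C1(Cc2ccccc2)CCN(c2cc(C(F)(F)F)ccc2CNC(=O)Nc2ccc(CNS(C)(=O)=O)c(F)c2)CC1` gives 25 nM. Compound 2 `CN(C)C1(Cc2ccccc2)CCN(c2cc(C(F)(F)F)ccc2CNC(=O)NCc2ccc(NS(C)(=O)=O)c(F)c2)CC1` gives 85.9 nM. Compound 3 `CN(C)C1(Cc2ccccc2)CCN(c2cc(C(F)(F)F)ccc2CNC(=O)Nc2ccc(CNS(N)(=O)=O)c(F)c2)CC1` gives 120 nM, the highest of the three numbers; its gap to compound 2 is within the scatter, whereas the step of a 4.8-fold higher number from compound 1 to compound 3 (0.68 log units; beyond the scatter) lies beyond it. Compound 4 `CN(C)C1(Cc2ccccc2)CCN(c2cc(C(F)(F)F)ccc2CNC(=O)Nc2ccc(CO)c(F)c2)CC1` differs from compound 3 by hydroxy in place of sulfamoylamino on a saturated chain carbon bound to an aromatic carbon. Among the compounds with values here, no measured step covers this exact replacement. Within the data shown here, the only step that touches the same part of the molecule is a 4.8-fold higher number from compound 1 to compound 3 (0.68 log units; beyond the scatter), which shows that changing what sits on the sulfonyl sulfur shifts this assay by a modest amount. Removing the whole sulfamoylamino group and leaving only a hydroxy is a larger change than that, and the two sulfonyl-bearing compounds 1 and 2 both sit at or below compound 3. On this basis compound 4 is expected to give a somewhat higher number than compound 3, with the expected step being a 1.8-fold higher number from compound 3 to compound 4 (0.26 log units; within the scatter). The value for compound 4 is therefore estimated at 220 nM, with an expected range from 60 nM to 800 nM.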

Compound 4, half-maximal effective concentration: 81 nM
Compound 4: middle estimate off by 2.7-fold (0.43 log units), on the high side; measured number inside the range.
By their numbers in this assay, from the lowest: compound 1; then compounds 4, 2 and 3 (each within the scatter of the next).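

With sulfamoylamino replaced by hydroxy on a saturated chain carbon bound to an aromatic carbon, this assay gives a 1.5-fold lower number from compound 3 to compound 4 (0.17 log units; within the scatter), so the sulfonyl unit of compound 3 can be removed at this position, and a group of 5 heavy atoms reduced to 1, without a difference beyond the scatter. The earlier step showed only that the substituent on the sulfonyl sulfur matters, whereas hydroxy in place of methanesulfonamido gives a 3.2-fold higher number from compound 1 to compound 4 (0.51 log units; beyond the scatter); among the three groups compared at this position, methanesulfonamido alone therefore stands apart, and its number cannot be credited to the mere presence of a sulfonyl group, as sulfamoylamino shows. The data given here include no measurement that explains these numbers.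

On these data alone, it remains open whether a simple amine, a methoxy group or a carboxylic acid on this carbon would read closer to compound 1 or to compound 4. As far as these compounds go, it is equally open whether a longer chain carrying the hydroxy, or a methanesulfonamido group on a longer chain, would alter the number in this assay.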